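A few compounds are considered here, and "the series" means these few. Any claim that something is new, unique, unknown or untested is made for them only; others in the source may bear on it.

Compound 2 `C=Cc1c(CCC)nn(CCCN2CCN(c3ccc(C)cc3)CC2)c(=O)c1N` carries a propyl chain on the shared core. In a functional assay on the whole organism (Abdomen, strain Swiss) for inhibition, with Mus musculus as the target, with stated times of 30 min, 10 min and 5 min, at a dose of 40 mg/kg by the oral route (a lower number here means a weaker effect, a higher number a stronger effect of the compound at the dose given), compound 2 gives 22%. Among the compounds with values here, its only measured neighbour is compound 1 `C=Cc1c(CC)nn(CCCN2CCN(c3ccc(C)cc3)CC2)c(=O)c1N`, which in this assay gives 28%; the step of a number 6 percentage points lower from compound 1 to compound 2 (within the scatter) lies within the scatter, so the two numbers stand together rather than apart.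

Compound 3 `C=Cc1c(CCCC)nn(CCCN2CCN(c3ccc(C)cc3)CC2)c(=O)c1N` has not yet been measured. It differs from compound 2 by methyl in place of hydrogen on a saturated chain carbon, three bonds along the chain from an aromatic carbon, the same kind of change read one bond further out as propyl to butyl. Within the data shown here, the one measured step that bears on this change, a number 6 percentage points lower from compound 1 to compound 2 (within the scatter), lengthened the same chain by one carbon and gave nothing beyond the scatter. The same is therefore expected here: a step of a number 3 percentage points lower from compound 2 to compound 3 (within the scatter), not beyond the scatter. Compound 3 is estimated at 19%, with a range from 5% to 34%.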

Compound 3, a percentage reported as inhibition, in the whole organism at one dose (the size of the read-out at that dose, not a potency): 48%
Estimate against measurement, compound 3: 29 percentage points below; the whole stated range lies below it.
By their numbers in this assay, from the lowest: compounds 2 and 1 (each within the scatter of the next); then compound 3.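

In this assay, lengthening propyl to butyl gives a number 26 percentage points higher from compound 2 to compound 3 (beyond the scatter), and the wider change from ethyl to butyl gives a number 20 percentage points higher from compound 1 to compound 3 (beyond the scatter). This position therefore does respond to chain length, but not evenly: the ethyl and propyl compounds stand together within the scatter, and only the butyl chain stands apart, so the same added methyl can count for little at one point on the chain and for much more one bond further out. Nothing available explains why the butyl chain stands apart.

Three chains cannot show whether a pentyl chain would carry the number higher or bring it back down. They also leave open whether a branched isobutyl group of the same carbon count would match the straight butyl chain.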